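Cyclohexyl for isopropyl in a macrocyclic aldehyde series

A few compounds are considered here, and "the series" means these few. Any claim that something is new, unique, unknown or untested is made for them only; others in the source may bear on it.

Two macrocycles have been tested so far.

Compound 1, `CC(C)C[C@@H]1NC(=O)[C@@H](NC(=O)OCc2ccccc2)Cc2cn(nn2)CCCCNC(=O)CC[C@@H](C=O)NC1=O`: in an ADME assay on HG23 cells (Homo sapiens) for cytotoxicity, with a stated time of 72 h (a lower number here means that less compound is tolerated, a higher number that more compound is tolerated), compound 1 gives > 100000 nM.
Compound 2, `CC(C)C[C@@H]1NC(=O)[C@@H](NC(=O)OCc2ccccc2)Cc2cn(nn2)CCCCCCNC(=O)CC[C@@H](C=O)NC1=O`: in this assay compound 2 gives > 100000 nM.

Neither of these figures is a measured number; each is a limit of the assay. Compound 2 therefore stands at the limit, and so does the one other compound shown, so no ordering between the two can be read from these values, which both sit at the limit of > 100000 nM in this assay, at which 2 of the 2 values shown sit.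

Compound 3, `O=C[C@@H]1CCC(=O)NCCCCCCn2cc(nn2)C[C@H](NC(=O)OCc2ccccc2)C(=O)N[C@@H](CC2CCCCC2)C(=O)N1`, has not yet been measured. It differs from compound 2 in a single place: cyclohexyl in place of isopropyl on a saturated chain carbon bound to a saturated ring carbon. The shared core of compound 2 is otherwise kept.

Among the compounds with values here, no step between measured compounds exists here, and both measured values are limits, so there is nothing to anchor a shift in either direction. For compound 3 the expected step that the limit leaves unreadable from compound 2 to compound 3 is none beyond the scatter. The estimate for compound 3 in this assay is 150000 nM, with a range from 50000 nM to 500000 nM, and most likely the assay again reports only a limit.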

Compound 3, half-maximal cytotoxic concentration: > 100000 nM
Compound 3: a limit, no number; the forecaster's own chance of this, stated with the estimate: 80%; the middle value is on the limit's open side.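

In this assay compound 3 gives > 100000 nM, which is a limit of the assay and not a number. Within the data shown here, compound 2 also sits at a limit, and no step between compound 2 and compound 3 can be read. The compounds shown leave open whether cyclohexyl in place of isopropyl alters the half-maximal cytotoxic concentration at all, and where the true value of each compound lies.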